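Swapping an Amide Substituent on Two Related Cores

The source may hold more compounds than are shown below. What is called first, only, known or untested is meant among the compounds shown, and "the series" means these compounds.

Compound 1 `CC[C@@H](C)[C@H](NC(=O)c1ccc(Oc2nc3ccccc3nc2C)cc1)C(=O)OC` and compound 2 `Cc1nc2ccccc2nc1Oc1ccc(C(=O)N[C@@H](C)C(=O)O)cc1` share one core and differ only in the group carried on an amide-type nitrogen: 1-carboxyethyl in place of 1-(methoxycarbonyl)-2-methylbutyl on an amide-type nitrogen. In a functional assay on MCF7 cells (Homo sapiens) for antiproliferative activity, read by MTT assay, with a stated time of 48 h (a lower number here means a stronger inhibitor, a higher number a weaker inhibitor), compound 1 gives 36100 nM, while compound 2 gives 25600 nM. The step between them, a 1.4-fold lower number from compound 1 to compound 2 (0.15 log units; within the scatter), is too small to tell the two numbers apart.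

Compound 3 `CCCCCCCCCCCCNc1nc2ccccc2nc1Oc1ccc(C(=O)N[C@H](C(=O)OC)[C@H](C)CC)cc1` rests on a different core; how its core differs from that of compound 1 is not broken down here. In this assay compound 3 gives 43300 nM, a number that sits near those of compound 1 and compound 2.

Compound 4 `CCCCCCCCCCCCNc1nc2ccccc2nc1Oc1ccc(C(=O)N[C@@H](C)C(=O)O)cc1` arises from compound 3 by the same change: 1-carboxyethyl in place of 1-(methoxycarbonyl)-2-methylbutyl on an amide-type nitrogen. The place is the same in both pairs, an amide-type nitrogen whose other neighbour is a carbonyl carbon, so this is the same change, not merely one of the same kind. Because the earlier step of a 1.4-fold lower number from compound 1 to compound 2 (0.15 log units; within the scatter) stayed within the scatter, compound 4 is expected to show a similarly small step, a 1.4-fold lower number from compound 3 to compound 4 (0.15 log units; within the scatter). Compound 4 is therefore estimated at 31000 nM, with a likely range from 15000 nM to 65000 nM.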

Compound 4, half-maximal inhibitory concentration: 4110 nM
Estimate against measurement, compound 4: 7.5-fold (0.88 log units) above; the whole stated range lies above it.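

On the core of compound 3, the swap of 1-(methoxycarbonyl)-2-methylbutyl for 1-carboxyethyl on the amide-type nitrogen gives a large step in this assay, an 11-fold lower number from compound 3 to compound 4 (1.02 log units; beyond the scatter), whereas on the core of compound 1 the same swap gives a step too small to read. The size of this step therefore changes with the core, so a result from one core could not simply be carried over to the other: the same change on two cores in this assay, a 1.4-fold lower number (0.15 log units; within the scatter) from compound 1 to compound 2 and an 11-fold lower number (1.02 log units; beyond the scatter) from compound 3 to compound 4, 7.5-fold (0.87 log units) apart, beyond the scatter of two such steps

For the compounds shown here, this rests on only two pairs, so it shows no general rule for the series, and it does not show which feature of the two cores makes the difference or why.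

The swap also changes two things at once, the ester becoming a carboxylic acid and the side chain becoming shorter, and the compounds shown do not separate these. A 1-carboxy-2-methylbutyl or a 1-(methoxycarbonyl)ethyl group on the same nitrogen of each core would show how much each part contributes.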